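One Aryl Exchange on the Shared Core

A few compounds are considered here, and "the series" means these few. Any claim that something is new, unique, unknown or untested is made for them only; others in the source may bear on it.

Measured compounds:
- compound 1, `COc1ccc([C@@H]2C/C(=N/OCc3cn(-c4ccc(Cl)cc4C)nn3)c3cc(CC=C(C)C)c(OC)cc3O2)cc1`, giving 37%
- compound 2, `COc1cc2c(cc1CC=C(C)C)C(=O)C[C@@H](c1ccc(Oc3ccc(F)cc3)cc1)O2`, giving 37%

Both compounds were tested in a functional assay on MCF7 cells (Homo sapiens) for inhibition, read by sulforhodamine B assay, with a stated time of 48 h, tested at 50 uM; on this read-out lower numbers stand for less inhibition of growth and higher numbers for more inhibition of growth at the one concentration tested. In this assay compound 1 gives 37%, and compound 2 gives 37%. Compound 1 therefore stands level with compound 2 at the digits shown; its nearest neighbour on the numbers is compound 2, and the two values show no change beyond the usual scatter of this kind of measurement.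

Compound 3, `COc1ccc([C@@H]2C/C(=N/OCc3cn(-c4ccc(C#N)cc4)nn3)c3cc(CC=C(C)C)c(OC)cc3O2)cc1`, has not yet been measured in this assay. It is built from compound 1 by one change: 4-cyanophenyl in place of 4-chloro-2-methylphenyl on an aromatic nitrogen. The new group keeps the same count of heavy atoms and the same single six-membered aromatic ring of carbon only, but brings a nitrile in place of the chlorine and methyl.

Among the measured compounds shown here, no pair of measured compounds that differ in one place is available here, so the size of this kind of change cannot be read off a measured comparison. With only the level of compound 1 to go on, the step from compound 1 to compound 3 is expected to be small, in no clear direction, not beyond the scatter: a number 1 percentage points lower from compound 1 to compound 3 (within the scatter). Compound 3 is thus estimated to give about 36% in this assay, with a range from 20% to 55%.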

Compound 3, percent growth inhibition at one concentration: 40%
For compound 3 the middle estimate is 4 percentage points below the measured one, and the stated range covers the measured number.
By their numbers in this assay, from the lowest: compounds 1, 2 and 3 (each within the scatter of the next).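

In this assay, among the compounds shown here, the exchange of 4-chloro-2-methylphenyl for 4-cyanophenyl on an aromatic nitrogen gives a number 3 percentage points higher from compound 1 to compound 3 (within the scatter) and is the first measured step at this position. The two compounds share the shared core and differ only in this aryl group, so a nitrile can stand in place of the chlorine and methyl, with one hydrogen-bond acceptor added to the group, and the two readings still cannot be told apart. Nothing measured here offers a reason for this result or describes any property of either group.

Because the chlorine, the methyl and the nitrile all differ in this single step, the compounds leave open what each of these features would do alone, and a step that cancels out cannot be ruled out. They also leave open how the reading in this assay would respond to a group of another kind on this nitrogen, such as a plain butyl chain or a pyridine ring, since both aryl groups shown are six-membered aromatic rings of carbon only.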